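The compounds below may be only part of what the source reports. "The series", "measured", "known", "first", "only" and "open" are said of these compounds alone.

In a physicochemical assay for solubility (on this read-out higher numbers stand for higher solubility and lower numbers for lower solubility), three compounds have been measured so far. Compound 1 (`O=S(=O)(Nc1ncccn1)c1ccc2c(c1)CC[C@@H]2c1ccc(C(F)(F)F)cc1-c1ccc(F)nc1`) gives 40000 nM. Compound 2 (`Cn1nccc1-c1cc(C(F)(F)F)ccc1[C@H]1CCOc2cc(S(=O)(=O)Nc3ccc(F)cn3)ccc21`) gives 29000 nM, and compound 3 (`Cc1nc(-c2cc(C(F)(F)F)ccc2[C@H]2CCOc3cc(S(=O)(=O)Nc4nccs4)ccc32)co1`) gives 61000 nM. Compound 1 holds the middle number of the three, but it lies within the scatter of both neighbours, so the numbers do not set it apart from either.

The next compound to be tested is compound 4 (`Cc1ccc(-c2cc(C(F)(F)F)ccc2[C@H]2CCc3cc(S(=O)(=O)Nc4ncccn4)ccc32)cn1`). It keeps the core of compound 1 and changes a single group: methyl in place of fluoro on an aromatic carbon. The 6-fluoropyridin-3-yl of compound 1 thus becomes 6-methylpyridin-3-yl in compound 4. Among the measured compounds shown here, no pair of measured compounds isolates this change, so the data offer no direct precedent for it.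

For the measured compounds named here, the only guide is the spread of the three values. Compound 2 and compound 3 differ from compound 1 in several places, yet compound 2 stands at 29000 nM and compound 3 at 61000 nM. A single swap of this size is therefore expected to move this assay little, with no step beyond the scatter. The expected step is a 1.1-fold higher number from compound 1 to compound 4 (0.04 log units; within the scatter), which is estimated to remain within the scatter. For compound 4 the estimated value is 44000 nM, with an expected range of 17000 nM to 110000 nM.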

Compound 4, solubility: 47000 nM
Beside the measured number, compound 4's estimate is 1.1-fold (0.03 log units) below it; the range from low to high includes it.
By their numbers in this assay, from the lowest: compounds 2, 1, 4 and 3 (each within the scatter of the next, the first and the last beyond it).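

In this assay, among the compounds shown here, putting methyl in place of fluoro on the aromatic carbon next to the ring nitrogen amounts to a 1.2-fold higher number from compound 1 to compound 4 (0.07 log units; within the scatter), and this is the first step that isolates a single change. For the compounds shown here, with the rest of compound 1 held fixed, 6-fluoropyridin-3-yl and 6-methylpyridin-3-yl therefore cannot be told apart on this read-out at this position, para to a large group, something the earlier compounds could not show because they differ from one another in several places. Nothing among the data shown speaks to why the two groups read alike.

As far as these compounds go, what stays open is how this position responds to groups of another kind, since this pair exchanges one heavy atom for one heavy atom and says nothing about an amine, a methoxy group or a carboxylic acid in the same place. From the compounds shown here alone, it also remains open whether the same exchange of fluoro for methyl would read alike in the settings of compound 2 or compound 3, which differ from compound 1 elsewhere in the structure.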